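Swapping a Pyridyl for a Furyl on the Shared Core

The source may report more compounds than this note shows. Statements on the series, on what has been measured and on what is new or still open speak of the compounds shown alone.

Compound 3 `Oc1cccc(-c2cc(-c3ccncc3)nc(-c3ccccc3Cl)c2)c1` has no single number in a functional assay on DU-145 cells (Homo sapiens) for cytotoxicity, read by CCK-8 assay and cell counting, with a stated time of 2 days; on this read-out lower numbers stand for stronger inhibition and higher numbers for weaker inhibition; for compound 3 the result reported is "not determined" (no result reported). Compound 4 `Oc1cccc(-c2cc(-c3ccco3)nc(-c3ccccc3Cl)c2)c1` differs from it in one place: furan-2-yl in place of pyridin-4-yl on an aromatic carbon. Two measured compounds speak to the furan-2-yl group at this position. Compound 1 `Oc1cccc(-c2cc(-c3ccc(Cl)cc3)nc(-c3cccs3)c2)c1` gives 11600 nM in this assay, and compound 2 `Oc1cccc(-c2cc(-c3ccc(Cl)cc3)nc(-c3ccco3)c2)c1` gives 11400 nM. The step of a 1.0-fold lower number from compound 1 to compound 2 (0.01 log units; within the scatter) shows that furan-2-yl in place of thiophen-2-yl left the number essentially unchanged, and compound 2 carries the same furan-2-yl group that enters in compound 4. For the measured compounds named here, no measured step bears directly on the exchange of pyridin-4-yl for furan-2-yl, and compound 3 offers no number to start from, so the size and direction of the step in this assay cannot be read from the data. Compound 4 is therefore expected to land near the numbers of compound 1 and compound 2, with a wide range: the estimate for compound 4 is 12000 nM, between 4000 nM and 40000 nM.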

Compound 4, half-maximal inhibitory concentration: 1630 nM
For compound 4 the middle estimate is 7.4-fold (0.87 log units) above the measured one, outside the stated range (below it).
By their numbers in this assay, from the lowest: compound 4; then compounds 2 and 1 (each within the scatter of the next).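

The number moved when the chlorine changed place on the phenyl group, not when the five-membered ring changed. With furan-2-yl held constant, 2-chlorophenyl in place of 4-chlorophenyl gives a 7.0-fold lower number from compound 2 to compound 4 (0.84 log units; beyond the scatter) in this assay, whereas the earlier thiophen-2-yl to furan-2-yl exchange gave only a 1.0-fold lower number from compound 1 to compound 2 (0.01 log units; within the scatter). This position on the shared core is therefore sensitive to this change in a way the earlier pair could not reveal, though no measurement given here explains the step.

On these data alone, with no number for compound 3, the step from compound 3 to compound 4 cannot be read, so the effect of furan-2-yl in place of pyridin-4-yl stays unknown. Also open, as far as these compounds go, is whether 3-chlorophenyl, or an amine or a carboxylic acid on the phenyl ring, would shift the number further.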